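Exposure series: dimethylbenzyl to methylpyridinylmethyl amine

A few compounds are considered here, and "the series" means these few. Any claim that something is new, unique, unknown or untested is made for them only; others in the source may bear on it.

Working notes on a set of three measured amines sharing one core. Compound 1 `Cc1cccc(C)c1CN[C@]1(CCC(C)(C)C)C(=O)C(C2=NS(=O)(=O)c3cc(NS(C)(=O)=O)ccc3N2)=C(O)c2ccccc21` gives 953 nM in an in vivo ADME assay on the whole organism (strain Sprague-Dawley) for pharmacokinetics, with Rattus norvegicus as the target, at a dose of 5 mg/kg by the oral route; a lower number here means less compound in the circulation, a higher number more compound in the circulation at the dose given. Compound 2 `CC(C)CC[C@@]1(NCc2ccccc2)C(=O)C(C2=NS(=O)(=O)c3cc(NS(C)(=O)=O)ccc3N2)=C(O)c2ccccc21` gives 131 nM in this assay. Compound 3 `Cc1cccc(C)c1CNC1(CCC(C)(C)C)C(=O)C(C2=NS(=O)(=O)c3cc(NS(C)(=O)=O)ccc3N2)=C(O)c2ccccc21` gives 707 nM in this assay and stands second highest of the three numbers. For the measured compounds named here, compound 1 and compound 3 differ only in whether the stereocentre at the saturated ring carbon is drawn with a configuration, and the step of a 1.3-fold lower number from compound 1 to compound 3 (0.13 log units; within the scatter) is within the scatter; the only evidence on that pair is the fact that one of compounds 1 and 3 is drawn with a defined configuration and the other without, at the place where they differ. Compound 2 differs from compound 3 in more than one place, so its values are noted only as a lower number.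

The unmeasured compound 4 `Cc1cccc(CNC2(CCC(C)(C)C)C(=O)C(C3=NS(=O)(=O)c4cc(NS(C)(=O)=O)ccc4N3)=C(O)c3ccccc32)n1` carries 6-methylpyridin-2-yl in place of 2,6-dimethylphenyl on a saturated chain carbon bound to an amine nitrogen. Going by the values given here, no measured step in the set touches this part of the molecule, so no measured step bears on it; the single measured step concerns stereo drawing alone and is within the scatter. The expected step of a 1.4-fold lower number from compound 3 to compound 4 (0.15 log units; within the scatter) is therefore not set beyond the scatter in either direction, and the range is kept wide. Compound 4 is estimated at 500 nM in this assay, with a range from 150 nM to 1500 nM.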

Compound 4, maximal plasma concentration: 235 nM
Compound 4: the middle estimate sits 2.1-fold (0.33 log units) above what was measured, within the range that was stated.
By their numbers in this assay, from the lowest: compounds 2 and 4 (each within the scatter of the next); then compounds 3 and 1 (each within the scatter of the next).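

For the compounds shown here, exchanging 2,6-dimethylphenyl for 6-methylpyridin-2-yl on a saturated chain carbon bound to an amine nitrogen gives, in this assay, a 3.0-fold lower number from compound 3 to compound 4 (0.48 log units; beyond the scatter), so this position, which no earlier step touched, is one where a change of group moves the number beyond the scatter. Going by these compounds alone, the only earlier step concerned stereo drawing alone and stayed within the scatter, which makes this the first single-place change to do so; the entering group has 7 heavy atoms and 1 hydrogen-bond acceptor, against 8 heavy atoms and 0 hydrogen-bond acceptors in the group that leaves. Nothing at hand bears on why the number moves at this position.

The compounds shown leave open how much of the step belongs to the ring nitrogen and how much to the methyl group that leaves with it, since both change in the one step. They also leave open where a 2-methylbenzyl or a (6-methoxypyridin-2-yl)methyl group on the same amine nitrogen would stand, and whether a defined configuration at the saturated ring carbon would matter with the (6-methylpyridin-2-yl)methyl group in place.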